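A few compounds are considered here, and "the series" means these few. Any claim that something is new, unique, unknown or untested is made for them only; others in the source may bear on it.

Compound 1 `COc1cc(NC(=O)c2ccc(Cl)cc2)ccc1NS(C)(=O)=O` gives 70000 nM in an ADME assay on RAW264.7 cells (Mus musculus) for cytotoxicity, read by MTT assay, with a stated time of 48 h; a higher number here means a weaker inhibitor, a lower number a stronger inhibitor.
Compound 2 `COc1cc(NC(=O)c2ccc(Cl)c([N+](=O)[O-])c2)ccc1NS(C)(=O)=O` reaches only a limit of this assay, > 250000 nM, not a number.
Compound 3 `CCS(=O)(=O)Nc1ccc(NC(=O)c2ccc(Cl)cc2)cc1Cl` likewise reaches only a limit of this assay, > 250000 nM, not a number.

From compound 1 to compound 2 the change is nitro in place of hydrogen on an aromatic carbon. In this assay this produced an at least 3.5-fold higher number from compound 1 to compound 2 (0.55 log units; beyond the scatter), with compound 2 at the limit of > 250000 nM in this assay, at which 2 of the 3 values shown sit, so the true size of the step is not known. Compound 3 differs from compound 1 in more than one place; the difference between the two cores is not broken down here.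

Compound 4 `CCS(=O)(=O)Nc1ccc(NC(=O)c2ccc(Cl)c([N+](=O)[O-])c2)cc1Cl` is not yet measured. It differs from compound 3 by nitro in place of hydrogen on an aromatic carbon, the same change as from compound 1 to compound 2, made at a place described in the same words. Compound 3 already stands at the limit of this assay, and the earlier change gave a number that was at least modestly higher. Compound 4 is therefore expected to show a step that the limit leaves unreadable from compound 3 to compound 4, most likely again only a limit. The estimate for compound 4 is 300000 nM, between 150000 nM and 600000 nM.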

Compound 4, half-maximal inhibitory concentration: 125000 nM
Beside the measured number, compound 4's estimate is 2.4-fold (0.38 log units) above it; measured number below the stated range.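

In this assay the change of nitro in place of hydrogen on an aromatic carbon does not carry over from one core to the other, and the two steps run in opposite directions: the same change on two cores in this assay, an at least 3.5-fold higher number (0.55 log units; beyond the scatter) from compound 1 to compound 2 and an at least 2.0-fold lower number (0.30 log units; that floor lies within the scatter) from compound 3 to compound 4, at least 7.1-fold (0.85 log units) apart, beyond the scatter of two such steps. On the core of compound 3, the change gives an at least 2.0-fold lower number from compound 3 to compound 4 (0.30 log units; that floor lies within the scatter) and places it ortho to a chloro group, so the step read on the core of compound 1 is no guide to the result on this core. From the compounds shown here alone, the true sizes of both steps remain unknown, and one pair on each core does not show how general the reversal is: the limit of > 250000 nM in this assay, at which 2 of the 4 values shown sit.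

Going by these compounds, the two cores differ in more than one place, so it stays open whether the change of direction goes with the methoxy or chloro group, or with the methyl or ethyl chain on the sulfonyl group. On these data alone, it is also open whether an amine or a carboxylic acid in place of the nitro group would split the two cores in the same way.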